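Trimming the Ring Methyl of Compound 3

This account rests on a few compounds, and the source may have more. Where it says the series, first, only, none or still open, it means among the compounds named here.

Compound 3 `Cc1cc2c(cc1C(=O)N=C(N)N)S(=O)(=O)C(C)C2N` gives 2320 nM in a functional assay for inhibition, with Homo sapiens as the target (a lower number here means a stronger inhibitor, a higher number a weaker inhibitor), the highest number among the three measured. Compound 2 `Cc1cc2c(cc1C(=O)N=C(N)N)S(=O)(=O)CC2C` gives 182 nM and compound 1 `Cc1cc2c(cc1C(=O)N=C(N)N)S(=O)(=O)CC2C(C)C` gives 77 nM, both gaps lying beyond the scatter. Compound 4 `Cc1cc2c(cc1C(=O)N=C(N)N)S(=O)(=O)CC2N` is compound 3 with hydrogen in place of methyl on a saturated ring carbon. Going by the values given here, the one measured step at a saturated ring carbon is a 2.4-fold higher number from compound 1 to compound 2 (0.37 log units; beyond the scatter), where a smaller alkyl raised the number modestly; it concerns a different ring carbon, so it bears only loosely on this change. For compound 4 the expected step is a 1.5-fold higher number from compound 3 to compound 4 (0.18 log units; within the scatter), a modest rise or nothing beyond the scatter. Compound 4 is therefore estimated at 3500 nM, within 1200 nM to 10000 nM.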

Compound 4, half-maximal inhibitory concentration: 692 nM
The estimate for compound 4 lay 5.1-fold (0.70 log units) above the measured number; the whole stated range lies above it.
By their numbers in this assay, from the lowest: compound 1; then compound 2; then compound 4; then compound 3.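

In this assay, hydrogen in place of methyl on the saturated ring carbon next to the ring sulfur lowers the number (a 3.4-fold lower number from compound 3 to compound 4 (0.53 log units; beyond the scatter)), so this position responds to that methyl. Even without that methyl, amino on the other ring carbon gives a higher number than methyl (a 3.8-fold higher number from compound 2 to compound 4 (0.58 log units; beyond the scatter)) or isopropyl (a 9.0-fold higher number from compound 1 to compound 4 (0.95 log units; beyond the scatter)). Nothing available explains these steps. As far as these compounds go, whether ethyl or hydroxyl next to the ring sulfur would follow the same direction remains open. So does whether a dimethylamino group would behave like amino.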